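This account rests on a few compounds, and the source may have more. Where it says the series, first, only, none or still open, it means among the compounds named here.

Within the data shown here, in a functional assay on HCT-15 cells (Homo sapiens) for antiproliferative activity, read by sulforhodamine B assay (on this read-out higher numbers stand for weaker inhibition of growth and lower numbers for stronger inhibition of growth), compound 1 `CC(C)(C)CCOc1cccc(O)c1C(=O)/C=C/c1ccc(C(=O)O)cc1` gives a measured 2170 nM, the only true number available in this small set. Compound 2 `CC(C)=CCOc1cccc(O)c1C(=O)/C=C/c1ccc(O)cc1` carries a prenyl-type ether, named here 3-methylbut-2-en-1-yl, and its result is only a limit of the assay, > 30000 nM. The next compound, compound 3 `CC(C)CCOc1cccc(O)c1C(=O)/C=C/c1ccc(O)cc1`, keeps the rest of compound 2 and changes only this chain, from 3-methylbut-2-en-1-yl to isopentyl: isobutyl in place of 2-methylprop-1-en-1-yl on a saturated chain carbon bound to an oxygen on an aromatic ring. The change is isobutyl in place of 2-methylprop-1-en-1-yl, on a saturated chain carbon bound to an oxygen on an aromatic ring. Among the measured compounds shown here, no measured step in this assay speaks to this change, so no shift beyond the scatter is expected, in either direction. The expected step is a number no higher from compound 2 to compound 3 (the limit leaves the size open), and another result reported only as a limit is quite likely. For compound 3 the estimated value is 30000 nM, within an expected range of 10000 nM to 60000 nM.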

Compound 3, concentration for 50% growth inhibition: 10600 nM
The estimate for compound 3 lay 2.8-fold (0.45 log units) above the measured number; the range from low to high includes it.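

Replacing the 3-methylbut-2-en-1-yl chain with isopentyl gives an at least 2.8-fold lower number from compound 2 to compound 3 (0.45 log units; beyond the scatter) in this assay, the first sign that this ether chain matters to the read-out, even with the rest of the structure unchanged. The only difference counted is the loss of the one double bond outside aromatic rings, so that double bond and its saturated replacement are not interchangeable here. Compound 2 is reported only as a limit of the assay, > 30000 nM, and the full size of the step stays unknown for that reason: the limit of > 30000 nM in this assay, at which 1 of the 3 values shown sits.

Compound 1 differs from compound 3 in more than one place, so what its carboxylic acid contributes cannot be read apart from its chain. As far as these compounds go, it also remains open how a longer chain or an amine at this position would compare with isopentyl.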